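Swapping Cyclopentyl for Bromophenyl: Expected Cell Toxicity

The compounds below may be only part of what the source reports. "The series", "measured", "known", "first", "only" and "open" are said of these compounds alone.

Compound 1 `COc1ccc(CNC(=O)NC(=O)c2ccc(F)cc2)cc1` gives > 50000 nM
Compound 2 `COc1ccc(-c2cnc(NC(=O)C3CCCC3)n2C)cc1` gives > 100000 nM
Compound 3 `COc1ccc(-c2cnc(NC(=O)c3ccc(F)cc3)[nH]2)cc1` gives > 100000 nM

Of the compounds shown here, three have been tested in a toxicity assay on THP-1 cells (Homo sapiens) for inhibition; on this read-out lower numbers stand for higher toxicity in this test and higher numbers for lower toxicity in this test. None of them produced a number. For compound 1 the value is a limit of the assay, not a measured concentration. For compound 2 the value is likewise a limit. For compound 3 the value is also a limit. Compound 2 thus sits at the limit of > 100000 nM in this assay, at which 2 of the 3 values shown sit, together with compound 3. Compound 1 sits at the limit of > 50000 nM in this assay, at which 1 of the 3 values shown sits. On the numbers available, compound 2 is not toxic to these cells up to the highest concentration the test reached, and nothing separates it from the other two.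

Compound 4 `COc1ccc(-c2cnc(NC(=O)c3ccccc3Br)n2C)cc1` has not yet been measured. It differs from compound 2 by 2-bromophenyl in place of cyclopentyl on a carbonyl carbon. The carbonyl and the amide-type nitrogen next to it are kept, and the rest of the shared core is unchanged. Within the data shown here, no measured pair of compounds shows what this exchange does in this assay, so the expectation rests on compound 2 alone.

Compound 2 gives > 100000 nM in this assay, and it is expected that compound 4 will also stay at a limit rather than show measurable toxicity. The step of a number no higher from compound 2 to compound 4 (the limit leaves the size open) is therefore estimated to be none beyond the usual scatter. Compound 4 is expected to give 100000 nM, with a range from 30000 nM to 300000 nM.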

Compound 4, half-maximal cytotoxic concentration: > 100000 nM
Compound 4: only a limit was reported; the forecaster's own chance of this, stated with the estimate: 80%; the middle value sits exactly at the limit.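

In this assay compound 4 gives > 100000 nM, which is a limit and not a measured number. Compound 2 also stands at a limit, so no step can be read between compound 2 and compound 4. The compounds shown leave open whether 2-bromophenyl in place of cyclopentyl on a carbonyl carbon changes toxicity at all.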